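The compounds below may be only part of what the source reports. "The series", "measured", "known", "first", "only" and "open" are said of these compounds alone.

Measured compounds and their values:
- compound 1, `Cc1ncc([N+](=O)[O-])n1CCSc1nnc(-c2ccccc2)o1`: 20500 nM
- compound 2, `Cc1ncc([N+](=O)[O-])n1CCSc1nnc(-c2ccccc2N)o1`: 20100 nM
- compound 3, `Cc1ncc([N+](=O)[O-])n1CCSc1nnc(-c2cnccc2N)o1`: 29300 nM

All three were tested in a functional assay on MCF7 cells (Homo sapiens) for cytotoxicity, read by MTT assay, with a stated time of 48 h; a higher number here means a weaker inhibitor, a lower number a stronger inhibitor. Compound 1 sits among three numbers that do not separate from one another: from compound 1 to compound 2 the change is a 1.0-fold lower number from compound 1 to compound 2 (0.01 log units; within the scatter), and from compound 1 to compound 3 it is a 1.4-fold higher number from compound 1 to compound 3 (0.16 log units; within the scatter). Between compound 2 and compound 3 the step is a 1.5-fold higher number from compound 2 to compound 3 (0.16 log units; within the scatter).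

The new compound is compound 4, `Cc1ncc([N+](=O)[O-])n1CCSc1nnc(-c2ccc(N)nc2)o1`. Compared with compound 1 it differs in one place: 6-aminopyridin-3-yl in place of phenyl on an aromatic carbon

Among the measured compounds shown here, the step that bears most on this is the one from compound 1 to compound 3, where a ring nitrogen and an amino group also entered in place of the plain phenyl, giving a 1.4-fold higher number from compound 1 to compound 3 (0.16 log units; within the scatter). The amino group on its own gave a 1.0-fold lower number from compound 1 to compound 2 (0.01 log units; within the scatter). Both stayed within the scatter, so no shift beyond the scatter is expected in this assay for compound 4; the expected step is a 1.1-fold higher number from compound 1 to compound 4 (0.05 log units; within the scatter). Compound 4 is therefore estimated at 23000 nM, with a range from 12000 nM to 45000 nM.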

Compound 4, half-maximal inhibitory concentration: 26800 nM
The estimate for compound 4 lay 1.2-fold (0.07 log units) below the measured number; the measured number falls inside the stated range.
By their numbers in this assay, from the lowest: compounds 2, 1, 4 and 3 (each within the scatter of the next).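

In this assay, the 6-aminopyridin-3-yl group in compound 4 does not separate from any group seen so far at this aromatic carbon of the five-membered ring (a 1.3-fold higher number from compound 1 to compound 4 (0.12 log units; within the scatter); a 1.3-fold higher number from compound 2 to compound 4 (0.12 log units; within the scatter); a 1.1-fold lower number from compound 3 to compound 4 (0.04 log units; within the scatter)). The new comparison with compound 3 adds that the two aminopyridinyl groups, 4-aminopyridin-3-yl and 6-aminopyridin-3-yl, also read alike, so all four aromatic groups shown here give numbers within the scatter of one another. No measured evidence is available to explain this flat result.

On these data alone, all four compounds carry a six-membered aromatic ring at this place, so it remains open whether a small methyl group, a morpholine or a carboxylic acid-bearing phenyl would move the number beyond the scatter. As far as these compounds go, it also remains open whether a longer chain in place of the sulfur-linked ethyl chain would do so.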